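This account rests on a few compounds, and the source may have more. Where it says the series, first, only, none or still open, it means among the compounds named here.

Compound 1 `O=C(CCc1cccc2c1B(O)OC2)Nc1nccs1`: > 100000 nM (a limit of the assay)
Compound 2 `C#Cc1ccc(NC(=O)CCc2cccc3c2B(O)OC3)cc1`: 6300 nM
Compound 3 `C#Cc1cccc(NC(=O)CCc2cccc3c2B(O)OC3)c1`: 980 nM

In a functional assay on SK-OV-3 cells (Homo sapiens) for antiproliferative activity, read by MTT assay, with a stated time of 72 h (on this read-out higher numbers stand for weaker inhibition and lower numbers for stronger inhibition), the entry for compound 1 is a limit and not a number. Of the two actual numbers, compound 2 has the higher at 6300 nM, and compound 3 stands lower at 980 nM, a gap beyond the scatter.

Compound 4 `O=C(CCc1cccc2c1B(O)OC2)Nc1ccc(-c2ccccc2)cc1` carries phenyl in place of ethynyl on an aromatic carbon, para to a large group: phenyl in place of ethynyl on an aromatic carbon. Among the measured compounds shown here, no measured pair isolates this change, so no step beyond the scatter is expected in this assay, and neither direction is favoured. The expected step of a 1.1-fold lower number from compound 2 to compound 4 (0.02 log units; within the scatter) is accordingly small. For compound 4 the estimated value is 6000 nM, with an expected range from 1500 nM to 30000 nM.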

Compound 4, half-maximal inhibitory concentration: 48000 nM
Compound 4: middle estimate off by 8.0-fold (0.90 log units), on the low side; the whole stated range lies below it.
By their numbers in this assay, from the lowest: compound 3; then compound 2; then compound 4. At a limit, above all of these: compound 1.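

In this assay, the place on an aromatic carbon, para to a large group, proves sensitive to what it carries: phenyl in place of ethynyl weakens inhibition (a 7.6-fold higher number from compound 2 to compound 4 (0.88 log units; beyond the scatter)). Among the compounds shown here, the other compounds offered no pair that isolated a change at this place, so this is the only direct reading of it. Nothing given here accounts for the step.

As far as these compounds go, with only ethynyl and phenyl compared at this place, it stays open how an amine, a carboxylic acid or a cyclopropyl group would read. From the compounds shown here alone, it also stays open whether a phenyl ring carrying further groups would read the same.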